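A few compounds are considered here, and "the series" means these few. Any claim that something is new, unique, unknown or untested is made for them only; others in the source may bear on it.

In an ADME assay on MDBK cells (Bos taurus) for cytotoxicity; a lower number here means that less compound is tolerated, a higher number that more compound is tolerated:
- compound 1 `Ic1ccc(Cn2ccc3nc(-c4ccccc4)nc-3c2)cc1`: 22000 nM
- compound 2 `c1ccc(CCCn2ccc3nc(-c4ccccc4)nc-3c2)cc1`: > 100000 nM

The entry for compound 2 is a limit of the assay, not a number: it stands at the limit of > 100000 nM in this assay, at which 1 of the 2 values shown sits. Compound 3 `c1ccc(CCCCn2ccc3nc(-c4ccccc4)nc-3c2)cc1` carries benzyl in place of phenyl on a saturated chain carbon, three bonds along the chain from an aromatic nitrogen. Within the data shown here, the only measured step, an at least 4.5-fold higher number from compound 1 to compound 2 (0.65 log units; beyond the scatter), is a different change on that chain, so it is a loose guide. With compound 2 at > 100000 nM as the starting point, the expected change is small, with no clear shift beyond the scatter: an at least 1.1-fold lower number from compound 2 to compound 3 (0.07 log units; that floor lies within the scatter). For compound 3 the estimated value is 85000 nM, with an expected range of 30000 nM to 150000 nM.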

Compound 3, half-maximal cytotoxic concentration: 95000 nM
The estimate for compound 3 lay 1.1-fold (0.05 log units) below the measured number; the measured number falls inside the stated range.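

Swapping phenyl for benzyl on this chain gives an at least 1.0-fold lower number from compound 2 to compound 3 (0.02 log units; that floor lies within the scatter) in this assay, so this longer chain shows no drop that can be told from the scatter. The entry for compound 2 is a limit of the assay, not a number: the limit of > 100000 nM in this assay, at which 1 of the 3 values shown sits. The step is therefore only a floor, while compound 3 gives this position its first true number on a phenyl-ended chain.

Going by these compounds, how far compound 2 really lies past its limit stays open. So does whether an amine or a carboxylic acid on this chain would shift the number.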